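Ring-nitrogen methylation of compound 1: expected activity

The compounds below may be only part of what the source reports. "The series", "measured", "known", "first", "only" and "open" are said of these compounds alone.

Measured in a functional assay on SW-620 cells (Homo sapiens) for inhibition, read by MTT assay, with a stated time of 72 h; a higher number here means a weaker inhibitor, a lower number a stronger inhibitor:
compound 1 `Cc1ccc(S(=O)(=O)Nc2cc[nH]c(=O)n2)cc1` gives > 100000 nM, a limit of the assay rather than a number.
compound 2 `CSc1cc[nH]c(=O)n1` gives > 100000 nM, likewise a limit rather than a number.
compound 3 `O=C(CCl)Nc1cn(COC(CO)CO)c(=O)[nH]c1=O` gives 19000 nM.

Compound 1 therefore stands at the limit of > 100000 nM in this assay, at which 2 of the 3 values shown sit. Only compound 3 returns a number in this assay, and the two limiting values permit no ordering of compound 1 against compound 2. Compound 4 `Cc1ccc(S(=O)(=O)Nc2ccn(C)c(=O)n2)cc1` has not been measured. It differs from compound 1 by methyl in place of hydrogen on an aromatic nitrogen. No measured pair in the series differs in one place, so the effect of this change has no precedent among these compounds. With compound 1 sitting at the limit, any step toward weaker inhibition would go unrecorded, and a step toward stronger inhibition would have to be large before a number appears at all. The expectation is a step in this assay of no size beyond the scatter, most likely ending again at a limit. Compound 4 is accordingly expected at 100000 nM, within a range from 30000 nM to 300000 nM. In terms of the change, the estimate amounts to a number no higher from compound 1 to compound 4 (the limit leaves the size open).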

Compound 4, half-maximal inhibitory concentration: > 100000 nM
Compound 4: a limit, no number; the forecaster's own chance of this, stated with the estimate: 80%; the middle value lies on the limit itself.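

In this assay compound 4 gives > 100000 nM, a limit of the assay and not a number. Compound 1 also stands at a limit, so no step can be read between compound 1 and compound 4: the limit of > 100000 nM in this assay, at which 3 of the 4 values shown sit.

The compounds shown leave open whether methyl in place of hydrogen on an aromatic nitrogen changes inhibition at all, and in which direction.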